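Halogen exchange on the sugar ring of the cytosine nucleosides

This account rests on a few compounds, and the source may have more. Where it says the series, first, only, none or still open, it means among the compounds named here.

For the measured compounds named here, compound 3 `Nc1ccn(C2OC(CO)C(I)C2O)c(=O)n1` is measured in a functional assay on L5178Y cells (Mus musculus) for antiproliferative activity (on this read-out higher numbers stand for weaker inhibition and lower numbers for stronger inhibition), at 0.1 ug/mL, the second highest of the three numbers so far. Compound 1 `Nc1ccn(C2OC(CO)C(Br)C2O)c(=O)n1` gives 0.03 ug/mL in this assay and is the nearest neighbour; compound 2 `Nc1nc(=O)n(C2OC(CO)C(Cl)C2O)cc1F` gives 1 ug/mL in this assay and lies furthest away. Compound 2 differs from compound 3 in two places, so its number says nothing direct about a single halogen swap.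

Compound 4 `Nc1ccn(C2OC(CO)C(Cl)C2O)c(=O)n1` is the next member and differs from compound 3 by chloro in place of iodo on a saturated ring carbon.

Going by the values given here, the one measured step that bears on this change is the halogen exchange on the same saturated ring carbon, a 3.3-fold higher number from compound 1 to compound 3 (0.52 log units; beyond the scatter). It shows that the move from bromo to iodo costs activity. Whether chloro behaves like bromo or falls off in the other direction cannot be read from the measured compounds; compound 2 carries a chloro but also a fluoro on the base and cannot be separated into single steps.

Going back toward a smaller halogen, compound 4 is expected to give a modestly lower number than compound 3 in this assay, a 2.0-fold lower number from compound 3 to compound 4 (0.30 log units; within the scatter), with the bromo compound 1 at 0.03 ug/mL as a guide. The estimate for compound 4 is 0.05 ug/mL, with a range from 0.01 ug/mL to 0.3 ug/mL.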

Compound 4, concentration for 50% inhibition: 2 ug/mL
Compound 4: the middle estimate sits 40-fold (1.60 log units) below what was measured, outside the stated range (above it).
By their numbers in this assay, from the lowest: compound 1; then compound 3; then compounds 2 and 4 (each within the scatter of the next).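

Chloro in place of iodo on this saturated ring carbon gives a 20-fold higher number from compound 3 to compound 4 (1.30 log units; beyond the scatter) and chloro in place of bromo gives a 67-fold higher number from compound 1 to compound 4 (1.82 log units; beyond the scatter) in this assay and so the choice of halogen at this position carries far more weight than the bromo and iodo pair alone showed. The three halogens do not run in their periodic order: bromo gives the lowest number, iodo the next and chloro the highest, so the iodo compound rather than the chloro compound stands closest to the bromo compound. On the aromatic carbon the exchange reads differently, since hydrogen in place of fluoro gives a 2.0-fold higher number from compound 2 to compound 4 (0.30 log units; within the scatter) and with chloro on the ring carbon the two base variants cannot be told apart.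

Open, as far as these compounds go, is whether fluoro, a hydroxy group or an amine on this ring carbon would fall with chloro or with bromo, and whether the aromatic fluoro stays equally silent alongside bromo or iodo. No evidence at hand accounts for the order of the three halogens.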